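Urea Analogues and Inducible Nitric Oxide Synthase

This account rests on a few compounds, and the source may have more. Where it says the series, first, only, none or still open, it means among the compounds named here.

Two compounds share a core in which an amino-substituted benzene ring carries a hydroxylated three-carbon chain that ends in a urea. Compound 1, `COc1ccc(N)c(C(O)CCNC(=O)Nc2ccccc2)c1`, and compound 2, `CCCNC(=O)NCCC(O)c1cc(Cl)ccc1N`, were tested in an assay for inhibition of Nitric oxide synthase, inducible (Homo sapiens), read by scintillation counting, with a stated time of 30 min, tested at 1 mM; a lower number here means less inhibition, a higher number more inhibition at the concentration tested (going by the name of the read-out). There compound 2 gives 19.6%, while compound 1 gives 12.3%; the gap between these two numbers lies within the usual scatter of such measurements, so neither number can be called higher than the other. Both numbers are small, meaning little inhibition at the tested concentration.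

Compound 3, `Nc1ccc(Cl)cc1C(O)CCNC(=O)Nc1ccccc1`, has not yet been measured. It differs from compound 2 in one place: phenyl in place of propyl on an amide-type nitrogen. Since compound 1 already carries the phenyl on the same urea nitrogen and gives a number close to that of compound 2, no step beyond the scatter is expected. For compound 3 the expected result in this assay is 15%, between 4% and 27%, a step of a number 4.6 percentage points lower from compound 2 to compound 3 (within the scatter) that is estimated to stay within the scatter.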

Compound 3, a percentage reported as inhibition, at one concentration (the size of the read-out at that concentration, not a potency): 3.11%
Compound 3: the middle estimate sits 11.9 percentage points above what was measured, outside the stated range (below it).
By their numbers in this assay, from the lowest: compounds 3, 1 and 2 (each within the scatter of the next, the first and the last beyond it).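

In this assay, phenyl in place of propyl on an amide-type nitrogen gives a number 16.5 percentage points lower from compound 2 to compound 3 (beyond the scatter), so the group on this nitrogen can change the read-out, which compounds 1 and 2 could not show because they differ in two places. Chloro in place of methoxy on an aromatic carbon, with the phenyl kept, gives a number 9.2 percentage points lower from compound 1 to compound 3 (within the scatter), so this change shows no clear effect. Nothing shown here explains the drop seen with phenyl.

The phenyl step rests on one pair of compounds that both carry chloro, so it may not hold with methoxy on the aromatic carbon. Going by these compounds, whether a longer chain such as butyl, or a benzyl group, on the same nitrogen would track with propyl or with phenyl remains open.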